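From Ketone Chain to Hydroxy(phenyl)methyl at the Core

The source may report more compounds than this note shows. Statements on the series, on what has been measured and on what is new or still open speak of the compounds shown alone.

Three compounds have been measured in a functional assay on HL60/MX2 cells (Homo sapiens) for inhibition, with a stated time of 48 h; a higher number here means a weaker inhibitor, a lower number a stronger inhibitor:
compound 1 `C#CCOC(=O)C1=C(N)Oc2ccc(-c3cc(OC)cc(OC)c3)cc2C1CC(=O)CCC` gives 5400 nM;
compound 2 `CCOC(=O)CC1C(C(=O)OCC)=C(N)Oc2ccc(-c3cc(OC)cc(OC)c3)cc21` gives 1700 nM;
compound 3 `CCOC(=O)C1=C(N)Oc2ccc(-c3cc(OC)cc(OC)c3)cc2C1CC(=O)c1ccccc1` gives 41000 nM.

Compound 1 stands second highest of the three numbers, between compound 2 below it and compound 3 above it, both gaps beyond the scatter. Compound 4 `C#CCOC(=O)C1=C(N)Oc2ccc(-c3cc(OC)cc(OC)c3)cc2C1CC(O)c1ccccc1` differs from compound 1 by hydroxy(phenyl)methyl in place of propylcarbonyl on a saturated chain carbon bound to a saturated ring carbon. Going by the values given here, the only measured step that bears on this is a 24-fold higher number from compound 2 to compound 3 (1.38 log units; beyond the scatter), where phenyl took the place of ethoxy on a carbonyl carbon and inhibition weakened sharply. Among the compounds with values here, compound 4 likewise gains a phenyl ring, though its carbonyl becomes a hydroxy group, so no measured step matches the change fully. A weaker inhibitor than compound 1 is therefore expected, by a 3.7-fold higher number from compound 1 to compound 4 (0.57 log units; beyond the scatter). Compound 4 is estimated at 20000 nM, with a range from 5000 nM to 80000 nM.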

Compound 4, half-maximal inhibitory concentration: 54000 nM
The estimate for compound 4 lay 2.7-fold (0.43 log units) below the measured number, within the range that was stated.
By their numbers in this assay, from the lowest: compound 2; then compound 1; then compounds 3 and 4 (each within the scatter of the next).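

In this assay there is a 10-fold higher number from compound 1 to compound 4 (1.00 log units; beyond the scatter) when hydroxy(phenyl)methyl takes the place of propylcarbonyl, so a phenyl ring at this place goes with weaker inhibition even with the carbonyl gone. The earlier step, a 24-fold higher number from compound 2 to compound 3 (1.38 log units; beyond the scatter) on the same chain, kept its carbonyl, so the weakening now also covers a chain carrying a hydroxy group instead.

As far as these compounds go, the phenyl ring and the hydroxy group enter together here, so their separate shares stay unknown, and how an amine or a carboxylic acid on this chain would fare remains open. No data at hand explain the weakening.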